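A few compounds are considered here, and "the series" means these few. Any claim that something is new, unique, unknown or untested is made for them only; others in the source may bear on it.

Measured so far:
- compound 1 `N=C(N)N/N=C/c1ccc(OCc2ccc3no[n+]([O-])c3c2)cc1`, > 200 uM
- compound 2 `O=Cc1ccc(OCc2ccc3no[n+]([O-])c3c2)cc1`, < 50 uM
- compound 3 `O=Cc1cccc(OCc2ccc3no[n+]([O-])c3c2)c1`, 50 uM

In an ADME assay on cells (Erythrocyte, Homo sapiens), read by spectrophotometry and hemolysis, with a stated time of 24 h (on this read-out lower numbers stand for stronger inhibition and higher numbers for weaker inhibition), compound 2 gives < 50 uM, which is a limit of the assay and not a number. Compound 1 gives > 200 uM, likewise a limit. Among the compounds with values here, compound 3 gives 50 uM, the only plain number in the set.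

From compound 2 to compound 1 the change is a group of 6 heavy atoms (2 carbon, 4 nitrogen; no ring) in place of a group of 2 heavy atoms (1 carbon, 1 oxygen; no ring), on an aromatic carbon. The step is an at least 4.0-fold higher number from compound 2 to compound 1 (0.60 log units; beyond the scatter). Its size is known only as a bound, because the limit of < 50 uM in this assay, at which 1 of the 3 values shown sits, and because the limit of > 200 uM in this assay, at which 1 of the 3 values shown sits, set the two ends.

Compound 3 has the same atoms as compound 2 joined differently; the difference between the two cores is not broken down here.

Compound 4 `N=C(N)N/N=C/c1cccc(OCc2ccc3no[n+]([O-])c3c2)c1` has not yet been measured in this assay. From compound 3 to compound 4 the change is a group of 6 heavy atoms (2 carbon, 4 nitrogen; no ring) in place of a group of 2 heavy atoms (1 carbon, 1 oxygen; no ring), on an aromatic carbon. It is the same kind of change as that from compound 2 to compound 1, but the place differs: in compound 4 the entering group sits meta to a large group, whereas in compound 1 it sits para to a large group. For compound 4 the expected step is a 4.0-fold higher number from compound 3 to compound 4 (0.60 log units; beyond the scatter), which rests on the earlier step of an at least 4.0-fold higher number from compound 2 to compound 1 (0.60 log units; beyond the scatter) being carried over onto the core of compound 3. Compound 4 is therefore expected to give about 200 uM, estimated between 80 uM and 500 uM, with a fair chance that only a limit is reported.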

Compound 4, concentration for 50% inhibition: > 100 uM
Compound 4: only a limit was reported (the forecaster's own chance of this, stated with the estimate: 55%); the middle value does not contradict the limit.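

In this assay compound 4 gives > 100 uM, which is a limit of the assay and not a number. On the core of compound 3, replacing the formyl with the entering group gives an at least 2.0-fold higher number from compound 3 to compound 4 (0.30 log units; that floor lies within the scatter), so this pair alone does not show a step beyond the scatter, though the true step may be larger than its floor. The data fit the change carrying over from one core to the other, but they do not show that its size is the same on both, and neither step is known as more than a bound: the same change on two cores in this assay, an at least 4.0-fold higher number (0.60 log units; beyond the scatter) from compound 2 to compound 1 and an at least 2.0-fold higher number (0.30 log units; that floor lies within the scatter) from compound 3 to compound 4; the limit leaves it open whether they differ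

On these data alone, the two cores are compared for only one replacement of the formyl, so it remains open whether an amine, a carboxylic acid or a longer chain in that place would shift the reading in this assay in the same way on both cores. As far as these compounds go, with only bounds available for these two steps, any real difference between the cores also remains open, and settling it would need plain numbers at both ends of each step.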